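Benzimidazole-bearing acylurea series: fluoro for trifluoromethyl

This account rests on a few compounds, and the source may have more. Where it says the series, first, only, none or still open, it means among the compounds named here.

Measured so far:
compound 1 `Cc1ccc(NC(=S)NC(=O)c2ccc(OCc3ccc(C(F)(F)F)cc3)cc2)cc1-c1nc2ccccc2[nH]1` — 6500 nM
compound 2 `O=C(NC(=S)Nc1ccc(Cl)c(-c2nc3ccccc3[nH]2)c1)c1ccc(OCc2ccc(Cl)cc2Cl)cc1` — 3030 nM
compound 3 `Cc1ccc(NC(=O)NC(=O)c2ccc(OCc3cccc(C(F)(F)F)c3)cc2)cc1-c1nc2ccccc2[nH]1` — 13100 nM

In a functional assay on MGC-803 cells (Homo sapiens) for inhibition, read by MTT assay, with a stated time of 48 h (a lower number here means a stronger inhibitor, a higher number a weaker inhibitor), compound 3 gives 13100 nM, the highest number of the three. The gap to compound 1 lies within the usual scatter, so no order between them is claimed; the gap to compound 2 lies beyond it. Within the data shown here, no pair of measured compounds differs in one place, so no single step is available as a guide.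

Compound 4 `Cc1ccc(NC(=O)NC(=O)c2ccc(OCc3cccc(F)c3)cc2)cc1-c1nc2ccccc2[nH]1` differs from compound 3 in one place: fluoro in place of trifluoromethyl on an aromatic carbon. Among the measured compounds shown here, with no comparable step measured, the expected change from compound 3 to compound 4 is a 1.1-fold higher number from compound 3 to compound 4 (0.06 log units; within the scatter), not beyond the scatter. For compound 4 the estimated value in this assay is 15000 nM, in the range 6000 nM to 40000 nM.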

Compound 4, half-maximal inhibitory concentration: 44800 nM
Estimate against measurement, compound 4: 3.0-fold (0.48 log units) below; the whole stated range lies below it.
By their numbers in this assay, from the lowest: compound 2; then compounds 1 and 3 (each within the scatter of the next); then compound 4.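

In this assay, among these compounds, the change from 3-(trifluoromethyl)benzyl to 3-fluorobenzyl gives a 3.4-fold higher number from compound 3 to compound 4 (0.53 log units; beyond the scatter), the first step that can be read at a single place. This position therefore responds to the group it carries, with the smaller fluoro giving the weaker inhibitor in this one pair. Nothing available explains the shift.

Open, on these data alone, is whether a nitrile or a methoxy group on this carbon would track with fluoro or with trifluoromethyl. Also open, as far as these compounds go, is whether the same step holds in the thiocarbonyl compounds, compound 1 and compound 2.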